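The source may report more compounds than this note shows. Statements on the series, on what has been measured and on what is new or still open speak of the compounds shown alone.

Working notes on the series. Compound 1 `Cc1cc(C(=O)NCN2CCC(c3cccc[n+]3[O-])CC2)ccc1F` is the reference point here: in a functional assay on HEK293 cells for agonist activity at D(4) dopamine receptor (Homo sapiens), read by FLIPR (on this read-out lower numbers stand for an effect already at smaller amounts and higher numbers for an effect only at larger amounts of compound), compound 1 gives 50 nM. Among the compounds with values here, the only other measured member, compound 2 `O=C(CN1CCC(c2cccc[n+]2[O-])CC1)Nc1cccc(F)c1`, gives in this assay 160 nM. Compound 1 thus stands at the lowest of the two numbers, and compound 2 sits beyond the scatter from it; the two compounds differ in more than one place, and their values show no more than that compound 1 acts at a smaller amount than compound 2.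

Compound 3 `O=C(NCN1CCC(c2cccc[n+]2[O-])CC1)c1cnccc1Cl` has not yet been measured in this assay. It differs from compound 1 by 4-chloropyridin-3-yl in place of 4-fluoro-3-methylphenyl on a carbonyl carbon. Within the data shown here, no measured pair carries a change of this kind, and the expectation therefore rests on the value of compound 1 alone. A step of modest size is expected, with the number going up, close to the edge of the usual scatter rather than clearly beyond it.

Compound 3 is expected to give 100 nM in this assay, within a range from 30 nM to 400 nM. The expected step of a 2.0-fold higher number from compound 1 to compound 3 (0.30 log units; within the scatter) states this estimate.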

Compound 3, half-maximal effective concentration: 1290 nM
Beside the measured number, compound 3's estimate is 13-fold (1.11 log units) below it, outside the stated range (above it).
By their numbers in this assay, from the lowest: compound 1; then compound 2; then compound 3.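

Exchanging 4-fluoro-3-methylphenyl for 4-chloropyridin-3-yl on the carbonyl carbon gives a 26-fold higher number from compound 1 to compound 3 (1.41 log units; beyond the scatter) in this assay, so with the rest of the core of compound 1 unchanged, this position clearly responds to the group it carries. The exchange replaces a ring of carbon only with a ring holding one hetero atom, adds a hydrogen-bond acceptor, and also swaps the fluorine and methyl substituents for a chlorine, so this single pair cannot assign the step to any one of these differences. Nothing at hand gives a measured explanation for the size of this step.

As far as these compounds go, it remains open whether the ring nitrogen, the chlorine or the loss of the fluorine and methyl substituents accounts for the step, and a 4-chlorophenyl or an unsubstituted pyridin-3-yl on the same carbonyl carbon would help to separate these contributions. Also open, from the compounds shown here alone, is what each substituent of compound 1 contributes on its own, which a 4-fluorophenyl or a 3-methylphenyl at this place would address.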